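Methyl on the Bromoalkyl Chain of Acylurea Antiproliferatives

The compounds below may be only part of what the source reports. "The series", "measured", "known", "first", "only" and "open" are said of these compounds alone.

Compound 3 `O=C(CBr)Nc1cccc(C(=O)NC(=O)Nc2ccccn2)c1` gives 700 nM in a functional assay on CCRF-CEM cells (Homo sapiens) for antiproliferative activity, read by MTT assay, with a stated time of 72 h (a higher number here means a weaker inhibitor, a lower number a stronger inhibitor), the lowest of the two numbers shown. Compound 1 `CC(Br)C(=O)Nc1cccc(C(=O)NC(N)=O)c1` gives 1470 nM in this assay. Compound 2 `CC(Br)C(=O)Nc1cccc(C(=O)NC(=O)Nc2ccccc2)c1` gives > 20000 nM in this assay, which is a limit of the assay rather than a number, sitting at the limit of > 20000 nM in this assay, at which 1 of the 3 values shown sits. For the measured compounds named here, the one measured step, an at least 13-fold higher number from compound 1 to compound 2 (1.13 log units; beyond the scatter), touches a different part of the shared core and does not bear on the change at hand. Compound 4 `CC(Br)C(=O)Nc1cccc(C(=O)NC(=O)Nc2ccccn2)c1` differs from compound 3 by methyl in place of hydrogen on a saturated chain carbon bound to a bromine atom and a carbonyl carbon. Going by the values given here, compounds 1 and 3 differ in two places, so their two values show only that compound 3 sits lower. Among the compounds with values here, with no measured step on this methyl, the step is expected to stay small, a 1.3-fold higher number from compound 3 to compound 4 (0.11 log units; within the scatter), in no clear direction. Compound 4 is expected to give 900 nM, within 350 nM to 2500 nM.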

Compound 4, half-maximal inhibitory concentration: 6230 nM
The estimate for compound 4 lay 6.9-fold (0.84 log units) below the measured number, and the stated range ends below it.
By their numbers in this assay, from the lowest: compound 3; then compound 1; then compound 4. At a limit, above all of these: compound 2.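

In this assay the methyl on this saturated chain carbon proves to matter, with an 8.9-fold higher number from compound 3 to compound 4 (0.95 log units; beyond the scatter) for the change from bromomethyl to 1-bromoethyl. With 1-bromoethyl in place, the group on the amide-type nitrogen also moves the number: pyridin-2-yl in place of hydrogen gives a 4.2-fold higher number from compound 1 to compound 4 (0.63 log units; beyond the scatter) and pyridin-2-yl in place of phenyl gives an at least 3.2-fold lower number from compound 2 to compound 4 (0.50 log units; beyond the scatter) as a bounded step. The value of compound 2, > 20000 nM, is a limit of the assay.

The compounds shown leave open whether an ethyl group in place of this methyl, or a chlorine atom in place of the bromine, would shift the number further. Nothing measured here bears on why this methyl moves the number.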